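Series notes: chain on the ring nitrogen of the core

The compounds below may be only part of what the source reports. "The series", "measured", "known", "first", "only" and "open" are said of these compounds alone.

Measured so far:
compound 1 `CCCc1nc(C)c2cnn(CC3CC3)c(=O)n12` — > 48000 nM
compound 2 `CCCc1nc(C)c2c(C)nn(CCC)c(=O)n12` — > 48000 nM

In a functional assay for inhibition, with Homo sapiens as the target (on this read-out higher numbers stand for weaker inhibition and lower numbers for stronger inhibition), compound 1 gives only a limit, > 48000 nM, not a number. Compound 2 likewise gives only a limit in this assay, > 48000 nM. Going by the values given here, both values sit at the same bound of the assay (the limit of > 48000 nM in this assay, at which 2 of the 2 values shown sit), so compound 1 cannot be placed relative to compound 2 at all, and no measured step between the two is available.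

Compound 3 `CCCc1nc(C)c2cnn(CC(=O)OCC)c(=O)n12` is not yet measured. It differs from compound 1 in one place: ethoxycarbonyl in place of cyclopropyl on a saturated chain carbon bound to an aromatic nitrogen. Cut one bond further out, the change reads cyclopropylmethyl to (ethoxycarbonyl)methyl.

With compound 1 at the limit and nothing else on this change, no step beyond the scatter is expected from compound 1 to compound 3, in either direction; the outcome for compound 3 is expected to be another limit at the same bound, so the step that the limit leaves unreadable from compound 1 to compound 3 is an estimate only. Compound 3 is estimated at 60000 nM in this assay, with a range from 20000 nM to 200000 nM.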

Compound 3, half-maximal inhibitory concentration: > 48000 nM
Compound 3: no number, only a limit; the forecaster's own chance of this, stated with the estimate: 85%; the middle value lies beyond the limit too.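

In this assay compound 3 gives only a limit (> 48000 nM). No step from compound 1 to compound 3 can be read, and compound 3 cannot be placed against compound 1: the limit of > 48000 nM in this assay, at which 3 of the 3 values shown sit.

The compounds shown leave open whether any change on the shared core gives a readable number in this assay rather than another limit.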